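The source may hold more compounds than are shown below. What is called first, only, known or untested is meant among the compounds shown, and "the series" means these compounds.

Compound 1 `O=C(COc1ccncc1-c1ccc2ccccc2c1)N1CCOCC1` and compound 2 `O=C(O)COc1ccncc1-c1ccc2ccccc2c1` share one core, and compound 3 `Cn1ncc2cc(-c3cnccc3/C=C/C(=O)N3CCOCC3)ccc21` and compound 4 `Cn1ncc2cc(-c3cnccc3/C=C/C(=O)O)ccc21` share another; the difference between the two cores is not broken down here. In an assay on a protein complex for inhibition of CDK8/Cyclin C (Homo sapiens), with a stated time of 1 h, tested at 10 uM (on this read-out lower numbers stand for less inhibition and higher numbers for more inhibition at the one concentration tested (going by the name of the read-out)), compound 1 gives 9%, compound 2 gives 16% and compound 3 gives 95%. Compound 2 arises from compound 1 by hydroxy in place of morpholin-4-yl on a carbonyl carbon, a change that gave a number 7 percentage points higher from compound 1 to compound 2 (within the scatter). Compound 4 arises from compound 3 by hydroxy in place of morpholin-4-yl on a carbonyl carbon. This is the same kind of change, not the same one, since in the first pair the carbonyl carbon sits on a saturated chain carbon and in the second on a double-bonded chain carbon. Among the measured compounds shown here, with only one earlier step of this kind, and that one lying within the scatter at a low level of inhibition, the step from compound 3 to compound 4 is expected to be a number 25 percentage points lower from compound 3 to compound 4 (beyond the scatter), because compound 3 starts from 95% and so has room to lose. Compound 4 is therefore estimated at 70%, with a plausible span from 30% to 95%.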

Compound 4, a percentage reported as inhibition, at one concentration (the size of the read-out at that concentration, not a potency): 102%
Compound 4: the middle estimate sits 32 percentage points below what was measured; measured number above the stated range.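

In this assay, hydroxy in place of morpholin-4-yl on the carbonyl carbon gave a number 7 percentage points higher from compound 3 to compound 4 (within the scatter), and the same kind of change on the other core reads alike: the same change on two cores in this assay, a number 7 percentage points higher (within the scatter) from compound 1 to compound 2 and a number 7 percentage points higher (within the scatter) from compound 3 to compound 4, 0 percentage points apart, within the scatter of two such steps. So in the two pairs shown, this change carries from one core to the other without a step beyond the scatter, although the first pair starts from compound 1 at 9% and the second from compound 3 at 95%. Among the compounds shown here, this does not show that the swap is neutral in general, since it rests on only two pairs, and a percentage at a single concentration is not a potency, so any difference in potency within a pair would remain unseen.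

The compounds shown leave open how a simple amine or a methyl ester on the same carbonyl carbon would read, and what a longer chain would do. They also do not separate which part of the two cores goes with the large gap in inhibition between the pairs.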